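Moving a methoxy group on a sulfonate ester

The source may hold more compounds than are shown below. What is called first, only, known or untested is meant among the compounds shown, and "the series" means these compounds.

compound 1 `CN1CCN(c2ccc(S(=O)(=O)Oc3cc(Cl)c(Cl)cc3Cl)cc2)C1=O` gives 420 nM
compound 2 `CN1CCN(c2ccc(S(=O)(=O)Oc3cccc(I)c3)cc2)C1=O` gives 400 nM
compound 3 `CCN1CCN(c2ccc(S(=O)(=O)Oc3ccccc3OC)cc2)C1=O` gives > 100000 nM

These three compounds were tested in a functional assay on M21 cells (Homo sapiens) for antiproliferative activity, read by sulforhodamine B assay, with a stated time of 48 h (on this read-out lower numbers stand for stronger inhibition and higher numbers for weaker inhibition), and the values of compound 1 and compound 2 lie within the scatter of each other. The result for compound 3 is > 100000 nM and that is a limit of the assay, not a number.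

Compound 4 `CCN1CCN(c2ccc(S(=O)(=O)Oc3ccc(OC)cc3)cc2)C1=O` has the same atoms as compound 3, joined differently (4-methoxyphenyl in place of 2-methoxyphenyl on an oxygen). It carries 4-methoxyphenyl in place of 2-methoxyphenyl on an oxygen whose other neighbour is the sulfonyl sulfur. For the measured compounds named here, no measured pair here shows what such a change does, so the expectation stays loose. A shift towards stronger inhibition in this assay is expected, since compound 2 at 400 nM shows that measured results of this strength occur in this set. Compound 4 may also remain at the limit. The estimated change is an at least 12-fold lower number from compound 3 to compound 4 (1.09 log units; beyond the scatter) and it is no more than an expectation. For compound 4 the estimated value is 8000 nM with an expected range from 800 nM to 80000 nM.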

Compound 4, half-maximal inhibitory concentration: 26000 nM
Compound 4: the middle estimate sits 3.3-fold (0.51 log units) below what was measured, and the stated range covers the measured number.
By their numbers in this assay, from the lowest: compounds 2 and 1 (each within the scatter of the next); then compound 4. At a limit, above all of these: compound 3.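

In this assay, 4-methoxyphenyl in place of 2-methoxyphenyl on an oxygen whose other neighbour is the sulfonyl sulfur gives an at least 3.8-fold lower number from compound 3 to compound 4 (0.58 log units; beyond the scatter). For the compounds shown here, this is the first pair here that differs in one place, and it shows that the same atoms, joined differently, can change the result beyond the scatter. Compound 3 stands at a limit rather than at a number, and the true size of the step stays unknown because of that: the limit of > 100000 nM in this assay, at which 1 of the 4 values shown sits.

On these data alone, whether an amine or a carboxylic acid in place of the methoxy group of 4-methoxyphenyl would give a lower or a higher number remains open. Also open, as far as these compounds go, is whether the same move from 2-methoxyphenyl to 4-methoxyphenyl would have a similar effect on the core of compound 1.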